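The source may report more compounds than this note shows. Statements on the series, on what has been measured and on what is new or still open speak of the compounds shown alone.

Measured so far in an ADME assay on HCT-116 cells (Homo sapiens) for cytotoxicity, read by CellTiter-Glo, with a stated time of 72 h; a lower number here means a stronger inhibitor, a higher number a weaker inhibitor:
Compound 1 `CC1CCN(C2CCN(S(=O)(=O)c3cccc(C(F)(F)F)c3)CC2)CC1`: > 5000 nM
Compound 2 `Cc1ccc(-c2ccccc2S(=O)(=O)N2CCC(N3CCC(C)CC3)CC2)cc1`: > 5000 nM
Compound 3 `CC1CCN(C2CCN(S(=O)(=O)c3ccccc3Br)CC2)CC1`: > 5000 nM

Each of these entries is a limit of the assay, not a number. Compound 3 stands at > 5000 nM, which is a limit, so it offers no exact starting point. The other two compounds give no number to compare it with, as the record shows (the limit of > 5000 nM in this assay, at which 3 of the 3 values shown sit). For the measured compounds named here, the one measured step between closely related compounds, a step that the two limits leave unreadable from compound 2 to compound 3, has no readable size.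

Compound 4 `Cc1cccc(S(=O)(=O)N2CCC(N3CCC(C)CC3)CC2)c1` has not yet been measured. It carries 3-methylphenyl in place of 2-bromophenyl on a sulfonyl sulfur.

Going by the values given here, no measured step therefore points to a change of any particular size or direction. With compound 3 at > 5000 nM, itself a limit, no step beyond the usual scatter is expected in this assay, and another limit is the likeliest result. The expected step is a step that the limit leaves unreadable from compound 3 to compound 4. For compound 4 the estimated value is 6000 nM, with an expected range from 3000 nM to 12000 nM.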

Compound 4, half-maximal inhibitory concentration: > 5000 nM
Compound 4 was reported as a limit (the forecaster's own chance of this, stated with the estimate: 85%); the middle value does not contradict the limit.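

Compound 4 is reported only as a limit, as are compound 1 and compound 3, so neither step to compound 4 can be read: the limit of > 5000 nM in this assay, at which 4 of the 4 values shown sit.

The compounds shown leave open which group on the sulfonyl sulfur, if any, would give a readable value in this assay.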